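A few compounds are considered here, and "the series" means these few. Any claim that something is new, unique, unknown or untested is made for them only; others in the source may bear on it.

Series in a functional assay on SK-MEL-28 cells (Homo sapiens) for inhibition, read by MTT assay, with a stated time of 48 h; on this read-out higher numbers stand for weaker inhibition and lower numbers for stronger inhibition:
Compound 1 `Cc1ccc(-c2nc3ccccn3c2Sc2ccccc2)cc1`: > 100000 nM, a limit.
Compound 2 `COc1ccc(-c2nc3ccccn3c2Sc2ccccc2)cc1`: 83900 nM.
Compound 3 `CSc1ccc(-c2nc3ccccn3c2Sc2ccccc2)cc1`: not yet measured.

Among the compounds with values here, compound 2 holds the only actual number. Compound 3 carries methylsulfanyl in place of methoxy on an aromatic carbon, para to a large group: methylsulfanyl in place of methoxy on an aromatic carbon. Within the data shown here, the one measured step, an at least 1.1-fold lower number from compound 1 to compound 2 (0.07 log units; that floor lies within the scatter), rests on the limit of > 100000 nM in this assay, at which 1 of the 2 values shown sits, and gives no size to carry over. No shift beyond the scatter is therefore expected, in either direction. The estimated step is a 1.0-fold lower number from compound 2 to compound 3 (0.02 log units; within the scatter). For compound 3 the expected value is 80000 nM, with an estimated range of 35000 nM to 100000 nM.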

Compound 3, half-maximal inhibitory concentration: 67700 nM
Compound 3: the middle estimate sits 1.2-fold (0.07 log units) above what was measured, within the range that was stated.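

Within the data shown here, at this aromatic carbon, para to a large group, methylsulfanyl in place of methoxy gives the first step between two actual numbers in this assay (a 1.2-fold lower number from compound 2 to compound 3 (0.09 log units; within the scatter)), so the exchange of these two groups does not move the read-out beyond the scatter. Methylsulfanyl in place of methyl gives an at least 1.4-fold lower number from compound 1 to compound 3 (0.16 log units; that floor lies within the scatter) as a floor only, with compound 1 a limit: (the limit of > 100000 nM in this assay, at which 1 of the 3 values shown sits).

Still open, from the compounds shown here alone, is whether any other group on this carbon, such as an amine, a carboxylic acid or a longer chain, would shift the read-out beyond the scatter.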